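A methyl removed from an oxygen in compound 3

This account rests on a few compounds, and the source may have more. Where it says the series, first, only, none or still open, it means among the compounds named here.

For the measured compounds named here, compound 3 `COc1ccc(Nc2nc(/C=C/c3cc(OC)c(OC)c(OC)c3)nc3ccsc23)cc1` is the only one of three measured compounds to yield a number in a functional assay on L02 cells (Homo sapiens) for inhibition, read by Griess assay, with stated times of 1 h and 24 h; a higher number here means a weaker inhibitor, a lower number a stronger inhibitor: compound 3 gives 279000 nM. Compound 1 `CNc1nc(/C=C/c2cc(OC)c(OC)c(OC)c2)nc2ccsc12` gives > 1000000 nM, which is a limit of the assay and not a number. Compound 2 `CCN1CCN(c2nc(/C=C/c3cc(OC)c(OC)c(OC)c3)nc3ccsc23)CC1` likewise gives > 1000000 nM, again a limit. This is the limit of > 1000000 nM in this assay, at which 2 of the 3 values shown sit. The step that the two limits leave unreadable from compound 1 to compound 2 therefore cannot be read. The step of an at least 3.5-fold lower number from compound 1 to compound 3 (0.55 log units; beyond the scatter) and the step of an at least 3.5-fold lower number from compound 2 to compound 3 (0.55 log units; beyond the scatter) both run the same way: placing a 4-methoxyphenyl group on the nitrogen of the shared core gave the only measurable inhibition.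

Compound 4 `COc1cc(/C=C/c2nc(Nc3ccc(O)cc3)c3sccc3n2)cc(OC)c1OC` has not been measured. It differs from compound 3 in one place: hydrogen in place of methyl on an oxygen on an aromatic ring. Going by the values given here, no measured step touches this oxygen; the steps that exist all concern the group on the nitrogen, so they set the background but not the direction. Nothing in the data points either way, and the expected step of a 1.1-fold lower number from compound 3 to compound 4 (0.05 log units; within the scatter) is therefore none beyond the scatter. Compound 4 is accordingly estimated at 250000 nM in this assay, within 80000 nM to 800000 nM, with a real chance that only a limit is reported.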

Compound 4, half-maximal inhibitory concentration: > 1000000 nM
Compound 4 gave a limit, no number; the forecaster's own chance of this, stated with the estimate: 25%; at least 4.0-fold (0.60 log units) between middle value and limit.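

In this assay, replacing methoxy with hydroxy gives an at least 3.5-fold higher number from compound 3 to compound 4 (0.55 log units; beyond the scatter), a step that is beyond the usual scatter. For the compounds shown here, the earlier compounds showed only that exchanging the whole group on the nitrogen could separate a number from a limit, whereas this pair shows that a much smaller change, the loss of one methyl from the oxygen, is enough to lose the number, even though the (4-hydroxyphenyl)amino group keeps the rest of the (4-methoxyphenyl)amino group in place. The steps from compound 1 and from compound 2 to compound 4 cannot be read, because both ends of each step are limits: the limit of > 1000000 nM in this assay, at which 3 of the 4 values shown sit.

Going by these compounds, it remains open whether this oxygen needs a methyl in particular, or whether a longer chain such as ethyl would also give a number, as might an amine or a chlorine in place of the whole methoxy group. Compound 3 also carries other methoxy groups, and the compounds shown do not tell whether hydroxy in place of any of those would count in the same way.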